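Adding Ethyl to the Chain of Compound 2

This account rests on a few compounds, and the source may have more. Where it says the series, first, only, none or still open, it means among the compounds named here.

Small changes to a molecule can show which parts of it matter for activity in cells. In a functional assay on SW480 cells (Homo sapiens) for antiproliferative activity, read by MTT assay, with a stated time of 48 h (on this read-out higher numbers stand for weaker inhibition and lower numbers for stronger inhibition), compound 1 `CCCCCCC(CCO)n1cnc2c(Cl)ncnc21` gives 16700 nM. Compound 2 `CCCCCCC(CCO)n1c(Br)nc2c(Cl)ncnc21` gives 14100 nM, so these two compounds stand level within the usual scatter of repeated measurements.

The next compound, compound 3 `CCCCCCCCC(CCO)n1c(Br)nc2c(Cl)ncnc21`, keeps the bromo group of compound 2 and alters the saturated chain: ethyl in place of hydrogen on a saturated chain carbon, seven bonds along the chain from an aromatic nitrogen. In words, this is ethyl in place of hydrogen on a saturated chain carbon, seven bonds along the chain from an aromatic nitrogen.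

Among the compounds with values here, only one measured step is available as a guide, a 1.2-fold lower number from compound 1 to compound 2 (0.07 log units; within the scatter). It stays within the scatter, but it concerns bromo in place of hydrogen on an aromatic carbon, not the chain. Within the data shown here, no measured pair varies the chain, so the data give no firm direction for this change. The expected change is therefore no larger than the scatter, a 1.3-fold lower number from compound 2 to compound 3 (0.11 log units; within the scatter).

For compound 3, the estimated value in this assay is 11000 nM, with an expected range of 4500 nM to 22000 nM.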

Compound 3, half-maximal inhibitory concentration: 17800 nM
For compound 3 the middle estimate is 1.6-fold (0.21 log units) below the measured one; low and high end bracket the measured number.
By their numbers in this assay, from the lowest: compounds 2, 1 and 3 (each within the scatter of the next).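

In this assay, putting ethyl in place of hydrogen on a saturated chain carbon, seven bonds along the chain from an aromatic nitrogen, gives a 1.3-fold higher number from compound 2 to compound 3 (0.10 log units; within the scatter) and so leaves the two compounds level. Within the data shown here, this is the first measured step that touches the chain rather than an aromatic carbon, and it shows that this position can carry ethyl with no shift that stands out from the normal spread of repeated measurements. Nothing measured here accounts for this flat result, so it stands as an observation without an explanation.

Going by these compounds, a single step along the chain cannot show how far this tolerance extends, so it remains open whether a still longer chain, or an amine or a carboxylic acid at the same position, would move the number beyond the scatter. It also remains open whether ethyl would behave the same way without the bromo group, since the only chain step shown is one in which that group is present.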